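A Third Aryl Group on a Shared Core

The source may hold more compounds than are shown below. What is called first, only, known or untested is meant among the compounds shown, and "the series" means these compounds.

Of the compounds shown here, two built on the same core have been measured. Compound 1 `CCCCCCC(Sc1nc(Cl)cc(Nc2nc(-c3ccc(F)cc3F)cs2)n1)C(=O)O` carries a 2,4-difluorophenyl group, and in an assay for inhibition of Polyunsaturated fatty acid 5-lipoxygenase (Homo sapiens), read by HPLC, with stated times of 15 min and 10 min (a higher number here means a weaker inhibitor, a lower number a stronger inhibitor), compound 1 gives 1500 nM. Compound 2 `CCCCCCC(Sc1nc(Cl)cc(Nc2nc(-c3ccc([N+](=O)[O-])cc3)cs2)n1)C(=O)O` carries a 4-nitrophenyl group in the same place, and in this assay compound 2 gives 1400 nM. The step of a 1.1-fold lower number from compound 1 to compound 2 (0.03 log units; within the scatter) is small, so although compound 2 holds the lower of the two numbers, the gap to compound 1 lies within the scatter, and neither can be called the stronger inhibitor.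

Compound 3 `CCCCCCC(Sc1nc(Cl)cc(Nc2nc(-c3ccc(Cl)cc3Cl)cs2)n1)C(=O)O` has not been measured. It differs from compound 2 by a single change: 2,4-dichlorophenyl in place of 4-nitrophenyl on an aromatic carbon. Within the data shown here, only one measured step touches this part of the molecule, a 1.1-fold lower number from compound 1 to compound 2 (0.03 log units; within the scatter), and it shows that exchanging one aryl group for another at this place left the number essentially where it was. With nothing else to go on, the same outcome is expected here. Compound 3 is therefore estimated to give 1400 nM in this assay, with a range from 500 nM to 4000 nM. This expectation corresponds to a step of no change at the digits printed from compound 2 to compound 3 (within the scatter), none beyond the scatter.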

Compound 3, half-maximal inhibitory concentration: 800 nM
Compound 3: middle estimate off by 1.8-fold (0.24 log units), on the high side, within the range that was stated.
By their numbers in this assay, from the lowest: compounds 3, 2 and 1 (each within the scatter of the next).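

Among these compounds, with compound 3, this place on the shared core has now held three different aryl groups, and in this assay no step among them goes beyond the scatter. The exchange of 4-nitrophenyl for 2,4-dichlorophenyl (a 1.8-fold lower number from compound 2 to compound 3 (0.24 log units; within the scatter)) swaps a group with 2 hydrogen-bond acceptors for one with none, and the exchange of 2,4-difluorophenyl for 2,4-dichlorophenyl (a 1.9-fold lower number from compound 1 to compound 3 (0.27 log units; within the scatter)) replaces only the halogen atoms on the ring, so these quite different groups cannot be told apart in this assay. Nothing available here accounts for these aryl groups giving such similar numbers.

On these data alone, all three compounds keep a six-membered aromatic ring of carbon at this place, so it remains open whether an unsubstituted phenyl ring, a phenyl ring bearing an amine or a carboxylic acid, or an open alkyl chain in place of the ring would move the number beyond the scatter. As far as these compounds go, the rest of the shared core is identical in all three compounds, so it also remains open whether these aryl groups would stay this close with a shorter chain on the carboxylic acid.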